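This account rests on a few compounds, and the source may have more. Where it says the series, first, only, none or still open, it means among the compounds named here.

In a functional assay on HCT-116 cells (Homo sapiens) for antiproliferative activity, read by sulforhodamine B assay, with a stated time of 4 days (on this read-out lower numbers stand for stronger inhibition of growth and higher numbers for weaker inhibition of growth), compound 3 (`COc1cc(Cl)c(-c2nc(SCC(=O)N3CCC3)nc3[nH]cc(C#N)c23)cc1OC`) gives 28 nM. Compound 2 (`COc1cc(Cl)c(-c2nc(SCC(=O)NC(C)(C)C)nc3[nH]cc(C#N)c23)cc1OC`) gives 50 nM, and compound 1 (`COc1cc(Cl)c(-c2nc(SCC(=O)NC3CC3)nc3[nH]cc(C#N)c23)cc1OC`) gives 60 nM. The gap from compound 3 to compound 2 lies within the scatter, and the gap from compound 3 to compound 1 lies beyond it. Compound 4 (`CNC(=O)CSc1nc(-c2cc(OC)c(OC)cc2Cl)c2c(C#N)c[nH]c2n1`) follows from methylamino in place of azetidin-1-yl on a carbonyl carbon. Within the data shown here, two measured steps bear on this change in reverse, each bringing azetidin-1-yl in where an amide hydrogen stood: a 2.1-fold lower number from compound 1 to compound 3 (0.33 log units; beyond the scatter) and a 1.8-fold lower number from compound 2 to compound 3 (0.25 log units; within the scatter). The exchange of amide substituents changed little: a 1.2-fold lower number from compound 1 to compound 2 (0.08 log units; within the scatter). Losing azetidin-1-yl is therefore expected to give a small rise in this assay, near the edge of the scatter: a 2.0-fold higher number from compound 3 to compound 4 (0.29 log units; within the scatter). The estimate for compound 4 is 55 nM, with an expected range of 22 nM to 140 nM.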

Compound 4, concentration for 50% growth inhibition: 42 nM
The estimate for compound 4 lay 1.3-fold (0.12 log units) above the measured number; the range from low to high includes it.
By their numbers in this assay, from the lowest: compounds 3, 4, 2 and 1 (each within the scatter of the next, the first and the last beyond it).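

In this assay methylamino on this carbonyl carbon stays level with all three earlier amides: a 1.5-fold higher number from compound 3 to compound 4 (0.18 log units; within the scatter) and a 1.2-fold lower number from compound 2 to compound 4 (0.08 log units; within the scatter) and a 1.4-fold lower number from compound 1 to compound 4 (0.15 log units; within the scatter). Neither the four-membered ring of azetidin-1-yl nor the hydrogen-bond donor of methylamino separates compound 4 from compound 3 in this assay, and compound 4 also stays within the scatter of compound 1 and compound 2. No available measurement gives a reason for this flat response. Still open, on these data alone, is how this position responds to a carboxylic acid in place of the amide. Also open, as far as these compounds go, is the response to a longer chain ending in a morpholine ring on the amide nitrogen.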